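Swapping Sulfur for Oxygen in the Ring on the Thiocarbonyl

The source may hold more compounds than are shown below. What is called first, only, known or untested is meant among the compounds shown, and "the series" means these compounds.

Compound 2 `N/C(=N\NC(=S)N1CCSCC1)c1ccccn1` gives 86% in a functional assay on A-375 cells (Homo sapiens) for cytotoxicity, read by MTT assay, with a stated time of 72 h, tested at 30 uM (a higher number here means more inhibition of growth at the concentration tested, a lower number less inhibition of growth), the highest of the three numbers available, though its neighbours sit within the scatter of it: compound 1 `Cc1ccnc(/C(N)=N/NC(=S)N2CCSCC2)c1` gives 84.9%, and, differing from compound 2 in two places, compound 3 `Cc1cccc(/C(N)=N/NC(=S)N2CCCCC2)n1` gives 80.9%. Among the compounds with values here, the one step with a single change, a number 1.1 percentage points higher from compound 1 to compound 2 (within the scatter), concerns a methyl on the aromatic ring and says nothing about the ring attached to the thiocarbonyl carbon.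

Compound 4 `N/C(=N\NC(=S)N1CCOCC1)c1ccccn1` is the as yet unmeasured partner of compound 2. The change is morpholin-4-yl in place of thiomorpholin-4-yl on a thiocarbonyl carbon. Within the data shown here, no measured pair shows this exchange, so the only guidance is that all three measured compounds, with two different rings on the thiocarbonyl carbon, lie within the scatter of one another. The account therefore expects no step beyond the scatter; compound 4 is estimated at 83%, with a range from 70% to 93%. The step this estimate means, a number 3 percentage points lower from compound 2 to compound 4 (within the scatter), is expected to be small, with the upper end of the range bounded by what this read-out can report.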

Compound 4, percent growth inhibition at one concentration: 15%
The estimate for compound 4 lay 68 percentage points above the measured number, outside the stated range (below it).
By their numbers in this assay, from the lowest: compound 4; then compounds 3, 1 and 2 (each within the scatter of the next).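

In this assay, morpholin-4-yl in place of thiomorpholin-4-yl on a thiocarbonyl carbon is a large step, a number 71 percentage points lower from compound 2 to compound 4 (beyond the scatter), so this position is far from indifferent to the ring it carries, something the three earlier compounds, all within the scatter of one another, gave no sign of. The two groups match in the count of heavy atoms, in ring size, in hydrogen-bond donors and acceptors and in having no net charge, and they differ in sulfur against oxygen, so for this pair a change that leaves those counts untouched removes most of the growth inhibition seen at the concentration tested. Within the data shown here, the only other single change available, hydrogen in place of methyl on an aromatic carbon, gives a number 1.1 percentage points higher from compound 1 to compound 2 (within the scatter), which makes the ring exchange by far the larger of the two steps in this small set.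

From the compounds shown here alone, it remains open whether other groups on the thiocarbonyl carbon, such as piperazin-1-yl or an open-chain dimethylamino group, would give a number near that of compound 2 or near that of compound 4, and whether the same exchange has the same size on a core that keeps the aromatic methyl. Nothing available here gives a reason for the size of this step.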